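Cyclopropylmethyl in place of butyl on a pyridinone nitrogen

The source may hold more compounds than are shown below. What is called first, only, known or untested is meant among the compounds shown, and "the series" means these compounds.

Compound 1 `Cc1ncccc1Oc1ccc(-c2ccn(CC3CC3)c(=O)c2C#N)cc1`: 1070 nM
Compound 2 `CCCCn1ccc(-c2ccc(Oc3ccnc(C)c3)c(Cl)c2)c(C#N)c1=O`: 166 nM
Compound 3 `CCCCn1ccc(-c2ccc(Oc3cccnc3C)c(Cl)c2)c(C#N)c1=O`: 100 nM

In a functional assay on CHO cells for positive allosteric modulation of metabotropic glutamate receptor 2 (Homo sapiens), read by scintillation counting and GTPgammaS binding, with a stated time of 30 min (on this read-out higher numbers stand for an effect only at larger amounts of compound and lower numbers for an effect already at smaller amounts), compound 3 gives the lowest of the three numbers; the step of a 1.7-fold lower number from compound 2 to compound 3 (0.22 log units; within the scatter) stays within the scatter, while compound 1 stands beyond it. Compound 4 `Cc1ncccc1Oc1ccc(-c2ccn(CC3CC3)c(=O)c2C#N)cc1Cl` differs from compound 3 by cyclopropyl in place of propyl on a saturated chain carbon bound to an aromatic nitrogen. Among the measured compounds shown here, no measured step covers this change alone: compound 1 carries the same cyclopropylmethyl group but also lacks the chlorine of compound 3, so its value in this assay reflects two changes at once. The expectation for compound 4 therefore rests on little; a step of a 2.5-fold higher number from compound 3 to compound 4 (0.40 log units; beyond the scatter) toward a higher number is estimated. Compound 4 is expected to give 250 nM, within 80 nM to 800 nM.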

Compound 4, half-maximal effective concentration: 230 nM
The estimate for compound 4 lay 1.1-fold (0.04 log units) above the measured number; the measured number falls inside the stated range.
By their numbers in this assay, from the lowest: compounds 3, 2 and 4 (each within the scatter of the next, the first and the last beyond it); then compound 1.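

With the chlorine held in place, cyclopropyl in place of propyl on a saturated chain carbon bound to an aromatic nitrogen can now be read alone in this assay, and a 2.3-fold higher number from compound 3 to compound 4 (0.36 log units; beyond the scatter) is a modest rise beyond the scatter. Chloro in place of hydrogen on an aromatic carbon can also be read alone: a 4.7-fold lower number from compound 1 to compound 4 (0.67 log units; beyond the scatter) is likewise beyond the scatter, so the two changes that compound 1 carried at once are now separated. No evidence at hand explains either step.

On these data alone, whether a longer chain or a chain ending in an amine would be tolerated on that nitrogen remains open. So does whether fluoro or methoxy could take the place of chloro on that aromatic carbon.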